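Fluorine added to a dimethylphenyl amide: expected solubility

A few compounds are considered here, and "the series" means these few. Any claim that something is new, unique, unknown or untested is made for them only; others in the source may bear on it.

Measured so far:
- compound 1, `COc1ccc2nc(C)cc(OCC(=O)Nc3cc(C)cc(C)c3)c2c1`: 26000 nM
- compound 2, `COc1ccc2nc(C)cc(OCC(=O)Nc3c(C)cccc3C)c2c1`: 112000 nM

Both compounds share the same core and differ only in the pattern of methyl groups on the phenyl ring attached to the amide nitrogen. In a physicochemical assay for solubility, in phosphate buffer, measured as kinetic solubility, with a stated time of 1 h, at pH 7.4 (a lower number here means a less soluble compound, a higher number a more soluble compound), compound 2 gives the higher of the two numbers; the step of a 4.3-fold higher number from compound 1 to compound 2 (0.63 log units; beyond the scatter) shows that moving the two methyl groups changed the value beyond the scatter.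

Compound 3, `COc1ccc2nc(C)cc(OCC(=O)Nc3cc(C)c(F)c(C)c3)c2c1`, has not yet been measured. It differs from compound 2 by 4-fluoro-3,5-dimethylphenyl in place of 2,6-dimethylphenyl on an amide-type nitrogen. This change returns the methyl groups to the arrangement found in compound 1 and adds a fluorine. Among the measured compounds shown here, the only measured step that bears on it is a 4.3-fold higher number from compound 1 to compound 2 (0.63 log units; beyond the scatter), read in reverse: compound 1 with the 3,5-dimethyl pattern sits clearly lower than compound 2. For the measured compounds named here, no measured pair tells what the added fluorine does here, so that part is uncertain.

Compound 3 is therefore expected to show a lower number than compound 2, a step of about a 6.6-fold lower number from compound 2 to compound 3 (0.82 log units; beyond the scatter). The estimate for compound 3 in this assay is 17000 nM, with a range from 5000 nM to 50000 nM.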

Compound 3, solubility: 31500 nM
The estimate for compound 3 lay 1.9-fold (0.27 log units) below the measured number, within the range that was stated.
By their numbers in this assay, from the lowest: compounds 1 and 3 (each within the scatter of the next); then compound 2.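

In this assay the fluoro in place of hydrogen on an aromatic carbon now has a measured pair of its own, and a 1.2-fold higher number from compound 1 to compound 3 (0.08 log units; within the scatter) shows that compound 1 and compound 3 cannot be told apart in this measurement. The other new step, a 3.6-fold lower number from compound 2 to compound 3 (0.55 log units; beyond the scatter), lies beyond the scatter, as does a 4.3-fold higher number from compound 1 to compound 2 (0.63 log units; beyond the scatter), so among these three amides the compound with the 2,6-dimethylphenyl group stands apart from the two whose methyl groups follow the 3,5-dimethyl pattern, with or without the fluorine. The numbers describe this difference but do not explain it, as no measurement shown here gives a reason for it.

As far as these compounds go, whether fluoro in place of hydrogen would also leave the number within the scatter on the 2,6-dimethylphenyl group remains open, as this one pair covers only the 3,5-dimethyl pattern. From the compounds shown here alone, it is also open how this assay would read with another group in the fluorine's place, such as a chlorine, a methoxy group, a nitrile or an amine.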